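Replacing the methylurea in a tetralin sulfone series

The source may hold more compounds than are shown below. What is called first, only, known or untested is meant among the compounds shown, and "the series" means these compounds.

Three measured analogues share the core of compound 1, `CN(C)S(=O)(=O)NC[C@@H]1CCCc2cc(S(=O)(=O)c3cccc(F)c3)ccc21`, and differ only in the group attached to the exocyclic amine. In an assay on isolated protein for displacement of a labelled ligand from 5-hydroxytryptamine receptor 6 (Homo sapiens) (on this read-out lower numbers stand for stronger inhibition and higher numbers for weaker inhibition), compound 1 gives 2 nM. Compound 2, `O=S(=O)(O)CCCNC[C@@H]1CCCc2cc(S(=O)(=O)c3cccc(F)c3)ccc21`, gives 1.26 nM, and the pair shows a 1.6-fold lower number from compound 1 to compound 2 (0.20 log units; within the scatter). Compound 3, `CN(C[C@@H]1CCCc2cc(S(=O)(=O)c3cccc(F)c3)ccc21)C(N)=O`, gives 39.8 nM, the highest number of the three: the change from the sulfamide reads a 20-fold higher number from compound 1 to compound 3 (1.30 log units; beyond the scatter), and from the sulfonic acid a 32-fold higher number from compound 2 to compound 3 (1.50 log units; beyond the scatter). Both steps point the same way and both are large, so the carbamoyl(methyl)amino group is the weak point of this small set.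

Compound 4, `CC(C)(C)C(=O)NC[C@@H]1CCCc2cc(S(=O)(=O)c3cccc(F)c3)ccc21`, carries the change (((tert-butyl)carbonyl)amino in place of carbamoyl(methyl)amino on a saturated chain carbon bound to a saturated ring carbon). Among the compounds with values here, no measured pair covers an amide of this kind, so the two steps into compound 3 are the only guide, and they say that leaving the carbamoyl(methyl)amino group has twice been accompanied by a much lower number. The pivaloyl amide is not a sulfamide and not a charged chain, so a full return to the level of compound 1 or compound 2 is not assumed; a partial recovery is the more cautious reading. The expected step is a 4.0-fold lower number from compound 3 to compound 4 (0.60 log units; beyond the scatter). Compound 4 is therefore estimated at 10 nM, within a range from 2.5 nM to 40 nM.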

Compound 4, inhibition constant: 3.98 nM
Compound 4: middle estimate off by 2.5-fold (0.40 log units), on the high side, and the stated range covers the measured number.
By their numbers in this assay, from the lowest: compounds 2, 1 and 4 (each within the scatter of the next, the first and the last beyond it); then compound 3.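

Moving to ((tert-butyl)carbonyl)amino on a saturated chain carbon bound to a saturated ring carbon gives, in this assay, a 10-fold lower number from compound 3 to compound 4 (1.00 log units; beyond the scatter), so a third group leaving carbamoyl(methyl)amino goes with a lower number, and this one is a simple amide with no net charge. Within the data shown here, the sulfamide and the 3-sulfopropyl chain are therefore not the only groups on this nitrogen that give low numbers: the comparison with the sulfamide shows a 2.0-fold higher number from compound 1 to compound 4 (0.30 log units; within the scatter), which leaves the two unordered, while a 3.2-fold higher number from compound 2 to compound 4 (0.50 log units; beyond the scatter) keeps compound 2 apart from compound 4. The entering and leaving groups have the same counts of hydrogen-bond donors and acceptors, yet differ in heavy atoms and in their arrangement, and no independent evidence here identifies which of these differences underlies the step.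

The compounds shown leave open whether the methyl on the nitrogen of compound 3 or the urea itself goes with the higher number, a question that carbamoylamino, the same urea without that methyl, would address. They also leave open whether the tert-butyl group matters, which an acetyl amide or a methyl carbamate on the same nitrogen would test.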